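The source may report more compounds than this note shows. Statements on the series, on what has been measured and on what is new or still open speak of the compounds shown alone.

Compound 3 `O=C(/C=C/c1ccc2c(c1)B(O)OC2)c1cccc(F)c1` is measured in a toxicity assay on MCF-10A cells (Homo sapiens) for cytotoxicity, read by MTT assay, with a stated time of 48 h (a higher number here means a weaker inhibitor, a lower number a stronger inhibitor), and gives 15800 nM. Its nearest neighbour is compound 1 `O=C(/C=C/c1ccc2c(c1)B(O)OC2)c1cccs1`, which in this assay gives 13800 nM; the step of a 1.1-fold higher number from compound 1 to compound 3 (0.06 log units; within the scatter) lies within the scatter, so the two sit together. Compound 2 `O=C(/C=C/c1ccc2c(c1)B(O)OC2)c1ccc(I)cc1` in this assay reaches only a limit, > 100000 nM (the limit of > 100000 nM in this assay, at which 1 of the 3 values shown sits). Compound 4 `COc1cccc(C(=O)/C=C/c2ccc3c(c2)B(O)OC3)c1` differs from compound 3 by methoxy in place of fluoro on an aromatic carbon. Among the compounds with values here, no measured step swaps one substituent for another on that ring; the bearing steps are an at least 6.3-fold lower number from compound 2 to compound 3 (0.80 log units; beyond the scatter), at least modest, and a 1.1-fold higher number from compound 1 to compound 3 (0.06 log units; within the scatter), within the scatter. A change no larger than the scatter is therefore expected, the estimated step being a 1.1-fold higher number from compound 3 to compound 4 (0.03 log units; within the scatter). Compound 4 is estimated at 17000 nM, ranging from 6000 nM to 60000 nM.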

Compound 4, half-maximal inhibitory concentration: 7400 nM
The estimate for compound 4 lay 2.3-fold (0.36 log units) above the measured number; low and high end bracket the measured number.
By their numbers in this assay, from the lowest: compounds 4, 1 and 3 (each within the scatter of the next, the first and the last beyond it). At a limit, above all of these: compound 2.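

Within this assay the exchange on this aromatic carbon, meta to a large group, gives a 2.1-fold lower number from compound 3 to compound 4 (0.33 log units; beyond the scatter) and so counts as a modest step. The earlier compounds shown here compared only whole groups on the carbonyl carbon, whereas this pair shows that exchanging one substituent on the ring can itself move the number beyond the scatter. Nothing in the data shown accounts for this step.

From the compounds shown here alone, whether an amine or an ethoxy group on the same carbon would move the number further remains open. So does whether methoxy on another carbon of that ring would act in the same way.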